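A few compounds are considered here, and "the series" means these few. Any claim that something is new, unique, unknown or untested is made for them only; others in the source may bear on it.

In a functional assay on Ehrlich cells (Mus musculus) for cytotoxicity, read by trypan blue exclusion, with a stated time of 2 h, tested at 100 ug/mL (on this read-out lower numbers stand for a weaker effect and higher numbers for a stronger effect at the one concentration tested), compound 1 `N#CC1=C(N)N(c2ccc(S(N)(=O)=O)cc2)C2=C(CCCC2)C1c1ccccc1` gives 30%, while compound 2 `N#CC1=C(N)N(c2ccc(S(N)(=O)=O)cc2)C2=C(CCCC2)C1c1ccc(O)cc1` gives 100%, a rise of a number 70 percentage points higher from compound 1 to compound 2 (beyond the scatter). Compound 2 therefore stands highest of the two numbers. Compound 3 `N#CC1=C(N)N(c2ccc(S(N)(=O)=O)cc2)C2=C(CCCC2)C1/C=C/c1ccccc1` differs from compound 2 by 2-phenylethenyl in place of 4-hydroxyphenyl on a saturated ring carbon. For the measured compounds named here, the only measured step bearing on this is the hydroxy step a number 70 percentage points higher from compound 1 to compound 2 (beyond the scatter), and compound 3 loses that hydroxy; the 2-phenylethenyl itself is covered by no measurement. A large fall is expected. For compound 3 the expected step is a number 60 percentage points lower from compound 2 to compound 3 (beyond the scatter), giving an estimate of 40% with a range from 15% to 80%.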

Compound 3, a percentage reported as activity, at one concentration (the size of the read-out at that concentration, not a potency): 70%
Estimate against measurement, compound 3: 30 percentage points below, within the range that was stated.
By their numbers in this assay, from the lowest: compound 1; then compound 3; then compound 2.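

In this assay, for the compounds shown here, a hydroxy is not the only change at this saturated ring carbon that raises the number: 2-phenylethenyl in place of phenyl gives a number 40 percentage points higher from compound 1 to compound 3 (beyond the scatter). Even so, 4-hydroxyphenyl remains ahead of 2-phenylethenyl, with a number 30 percentage points lower from compound 2 to compound 3 (beyond the scatter). Nothing available explains either step. The compounds shown leave open whether a hydroxy on the aromatic ring of 2-phenylethenyl would raise the number further. They also leave open how an amine or a methoxy group in place of that hydroxy on 4-hydroxyphenyl would compare.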